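Tert-butyl to silicon swap on the alkyne of the nitrochromene core

This account rests on a few compounds, and the source may have more. Where it says the series, first, only, none or still open, it means among the compounds named here.

Measured so far:
- compound 1, `CC(C)(C)C#Cc1ccc2c(c1)C=C([N+](=O)[O-])C(C(F)(F)F)O2`: in an assay on isolated protein for inhibition of D(1B) dopamine receptor (Homo sapiens) (a lower number here means a stronger inhibitor, a higher number a weaker inhibitor), compound 1 gives 2100 nM
- compound 2, `O=C1c2ccccc2C(=O)N1CC#Cc1ccc2c(c1)C=C([N+](=O)[O-])C(C(F)(F)F)O2`: in this assay compound 2 gives 1400 nM

Compound 1 carries the higher of the two numbers recorded; the nearest neighbour is compound 2, and the gap between the two values lies within the scatter, so no order between them can be read from these data. Both compounds share the same core and differ only in the group capped onto the terminal triple-bonded carbon, and neither change in that position has yet produced a value that stands apart from the other.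

Compound 3, `C[Si](C)(C)C#Cc1ccc2c(c1)C=C([N+](=O)[O-])C(C(F)(F)F)O2`, is the next member, not yet measured. Relative to compound 1 the change is a group of 4 heavy atoms (3 carbon, 1 silicon; no ring) in place of a group of 4 heavy atoms (4 carbon; no ring), on a triple-bonded carbon. For the measured compounds named here, no step between two measured compounds isolates this kind of exchange, so the expectation rests only on the fact that the two cap groups measured so far gave values within the scatter of one another. The step is therefore expected to be small: the estimated step of a 1.1-fold lower number from compound 1 to compound 3 (0.02 log units; within the scatter) is one of no change beyond the scatter. Compound 3 is estimated at 2000 nM, with a range from 700 nM to 6000 nM.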

Compound 3, inhibition constant: 4200 nM
The estimate for compound 3 lay 2.1-fold (0.32 log units) below the measured number; low and high end bracket the measured number.
By their numbers in this assay, from the lowest: compounds 2, 1 and 3 (each within the scatter of the next, the first and the last beyond it).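

For the compounds shown here, the exchange of tert-butyl for the silicon-bearing group on the triple-bonded carbon gives a 2.0-fold higher number from compound 1 to compound 3 (0.30 log units; within the scatter) in this assay and is the first step that isolates a single swap at this position; it shows that replacing one carbon of the cap with silicon does not move the value beyond the scatter. Going by these compounds alone, the spread of caps is nevertheless wider than the earlier pair suggested: in this assay compound 2 gives 1400 nM and compound 3 gives 4200 nM as the first two values that lie beyond the scatter of each other, while compound 1 stays within the scatter of both. No independent measurement is available to account for this result.

Three caps on one shared core leave open how this assay would respond to a cap carrying an amine, a carboxylic acid or a longer alkyl chain, or to a bare hydrogen on the triple-bonded carbon. As far as these compounds go, it also remains open whether the same tert-butyl to silicon exchange would give a comparable step on a core with a different substitution pattern.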